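Swapping Methoxy for Chloro on a Weak Cytotoxic Hydrazone

The source may hold more compounds than are shown below. What is called first, only, known or untested is meant among the compounds shown, and "the series" means these compounds.

Compound 1, `COc1ccc(Cn2cc(/C=N\NC(=O)c3c[nH]c4ccccc34)c3cc(OC)ccc32)cc1`: 13600 nM
Compound 2, `COc1ccc(Cn2cc(/C=N\NC(=O)c3c[nH]c4ccc(Br)cc34)c3cc(OC)ccc32)cc1`: 28000 nM

Going by the values given here, in a functional assay on PC-3 cells (Homo sapiens) for cytotoxicity (a higher number here means a weaker inhibitor, a lower number a stronger inhibitor), compound 2 gives the higher of the two numbers measured so far, so it is the weaker inhibitor of the pair. Among the compounds with values here, the only measured step, a 2.1-fold higher number from compound 1 to compound 2 (0.31 log units; beyond the scatter), concerns a bromo group on the shared core and says nothing about the benzyl side. Compound 3, `COc1ccc2c(c1)c(/C=N\NC(=O)c1c[nH]c3ccc(Br)cc13)cn2Cc1ccc(Cl)cc1`, differs from compound 2 by chloro in place of methoxy on an aromatic carbon. Within the data shown here, with no measured step bearing on this position, the expected change is no change at the digits printed from compound 2 to compound 3 (within the scatter), none beyond the scatter. Compound 3 is therefore estimated at 28000 nM, within a range from 10000 nM to 75000 nM.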

Compound 3, half-maximal inhibitory concentration: 15900 nM
Compound 3: the middle estimate sits 1.8-fold (0.25 log units) above what was measured, and the stated range covers the measured number.
By their numbers in this assay, from the lowest: compounds 1, 3 and 2 (each within the scatter of the next, the first and the last beyond it).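

In this assay, replacing 4-methoxybenzyl with 4-chlorobenzyl gives a 1.8-fold lower number from compound 2 to compound 3 (0.25 log units; within the scatter) and so cannot be told apart from repeat-measurement noise. Going by these compounds alone, this is the first reading on the benzyl side, and it shows that this position accepts chloro in place of methoxy with no measurable shift in cytotoxicity. Nothing measured here offers an explanation for this result.

On these data alone, whether an amine, a carboxylic acid or a longer chain at this position would shift the number remains open. So does whether the same swap would read alike on the core of compound 1, which lacks the bromo group.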